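This account rests on a few compounds, and the source may have more. Where it says the series, first, only, none or still open, it means among the compounds named here.

Compound 1 `O=C(COc1cccc2ccccc12)N/N=C/c1ccc(Cl)cc1` gives 100 ug/mL in an ADME assay on HEL cells (Homo sapiens) for cytotoxicity; a higher number here means that more compound is tolerated, a lower number that less compound is tolerated.
Compound 2 `COc1ccc(/C=N/NC(=O)COc2cccc3ccccc23)cc1O` gives 27.7 ug/mL.
Compound 3 `O=C(COc1cccc2ccccc12)N/N=C/c1ccc([N+](=O)[O-])cc1` gives 14.2 ug/mL.

Compound 1 shows the highest number of the three; compound 2 lies nearer to it, and compound 3 further away. Among the measured compounds shown here, the one measured step, a 7.0-fold lower number from compound 1 to compound 3 (0.85 log units; beyond the scatter), is the only single change in that part of the molecule that has been followed. Compound 4 `O=C(COc1cccc2ccccc12)N/N=C/C=C/c1ccccc1` arises from compound 1 by 2-phenylethenyl in place of 4-chlorophenyl on a carbon with a double bond to nitrogen. For the measured compounds named here, no measured step exchanges the whole 4-chlorophenyl group for a 2-phenylethenyl group, so the nitro-for-chloro step serves only as a rough scale: a single change there moved the number by a modest but clear amount. Compound 4 is therefore expected to come in somewhat below compound 1, a 1.7-fold lower number from compound 1 to compound 4 (0.22 log units; within the scatter), although a step within the scatter cannot be ruled out. The estimate for compound 4 is 60 ug/mL, between 20 ug/mL and 150 ug/mL.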

Compound 4, half-maximal cytotoxic concentration: 100 ug/mL
Compound 4: middle estimate off by 1.7-fold (0.22 log units), on the low side; low and high end bracket the measured number.
By their numbers in this assay, from the lowest: compounds 3 and 2 (each within the scatter of the next); then compounds 1 and 4 (each within the scatter of the next).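

Set against the nitro-for-chloro change, which gave a 7.0-fold lower number from compound 1 to compound 3 (0.85 log units; beyond the scatter), the exchange of the whole group at this carbon gives no change at the digits printed from compound 1 to compound 4 (within the scatter) in this assay. The position therefore takes 2-phenylethenyl, with its added double bond outside aromatic rings, in place of 4-chlorophenyl without any shift in the number. No evidence here accounts for this result.

Open, on these data alone, is whether a group with no aromatic ring at this carbon, such as a plain butyl chain, would behave the same way. Also open, as far as these compounds go, is whether an amine or a carboxylic acid on the phenyl ring of compound 4 would move the number.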